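Hydroxy position and a fluoro entering the benzylidene ring

The source may hold more compounds than are shown below. What is called first, only, known or untested is meant among the compounds shown, and "the series" means these compounds.

Measured so far in an assay on isolated protein for inhibition of Amine oxidase [flavin-containing] B (Homo sapiens), read by fluorescence and spectrophotometry, with a stated time of 20 min; a lower number here means a stronger inhibitor, a higher number a weaker inhibitor:
compound 1 `O=C1/C(=C/c2ccccc2)Cc2cc(O)ccc21` gives 376 nM
compound 2 `O=C1/C(=C/c2ccccc2)Cc2ccc(O)cc21` gives 2420 nM

Compound 1 holds the lowest of the two numbers in this assay; compound 2 stands well apart from it, and the two values differ by more than the usual scatter. For the measured compounds named here, no step between measured compounds that differ in a single place is available, so nothing measured yet tells how a change on the benzylidene ring behaves in this assay.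

Compound 3 `O=C1/C(=C/c2cccc(F)c2)Cc2cc(O)ccc21` is obtained from compound 1 by the change (fluoro in place of hydrogen on an aromatic carbon), fluoro in place of hydrogen on an aromatic carbon. Going by the values given here, with only two measured compounds, which differ in the position of the hydroxy and not in the benzylidene ring, the step from compound 1 to compound 3 is expected to be small, a 1.3-fold lower number from compound 1 to compound 3 (0.10 log units; within the scatter), and not beyond the scatter. For compound 3 in this assay the estimate is 300 nM, with a range from 110 nM to 850 nM.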

Compound 3, half-maximal inhibitory concentration: 84 nM
For compound 3 the middle estimate is 3.6-fold (0.55 log units) above the measured one; the measured number lies below the stated range.
By their numbers in this assay, from the lowest: compound 3; then compound 1; then compound 2.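

In this assay, the benzylidene ring now has its first reading: a fluoro in place of hydrogen, on an aromatic carbon meta to a large group, gives a 4.5-fold lower number from compound 1 to compound 3 (0.65 log units; beyond the scatter). This ring therefore responds to substitution at this place, even though the entering fluoro is a single heavy atom with no hydrogen-bond donors or acceptors by the count. Nothing available accounts for the size of this step.

As far as these compounds go, it remains open whether the step belongs to fluoro itself or to this place on the ring; a chloro, a methyl or a methoxy on the same carbon would test the first, and fluoro on another carbon of the ring the second. Also open, from the compounds shown here alone, is whether the same fluoro would lower the number of compound 2, which carries its hydroxy elsewhere on the core.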